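The compounds below may be only part of what the source reports. "The series", "measured", "known", "first", "only" and "open" are said of these compounds alone.

Working notes on the series. The shared core of compound 1 `O=C(Nc1ccccc1)C1CCc2ccccc2N1` carries no acyl group on the ring nitrogen, and in a functional assay on HCT-15 cells (Homo sapiens) for cytotoxicity, read by sulforhodamine B assay, with a stated time of 72 h (on this read-out higher numbers stand for weaker inhibition of growth and lower numbers for stronger inhibition of growth), compound 1 gives 109000 nM. Compound 2 `O=C(Nc1cc(C(F)(F)F)cc(C(F)(F)F)c1)C1CCc2ccccc2N1C(=O)c1cccc(Cl)c1` gives 625 nM in this assay, and compound 3 `O=C(Nc1ccccc1C(F)(F)F)C1CCc2ccccc2N1C(=O)c1ccc(Cl)cc1` gives 839 nM. Compound 2 and compound 3 lie within the usual scatter of each other, while compound 1 sits far beyond it from both. Compound 4 `CCCCCCCCC(=O)N1c2ccccc2CCC1C(=O)Nc1cc(C(F)(F)F)cc(C(F)(F)F)c1` differs from compound 2 in one place: octyl in place of 3-chlorophenyl on a carbonyl carbon. Within the data shown here, no measured pair shows this change. The step of a 2.4-fold higher number from compound 2 to compound 4 (0.38 log units; beyond the scatter) is expected to be a modest loss, since compound 1 gives 109000 nM without any acyl group. For compound 4 the estimate in this assay is 1500 nM, within 400 nM to 6000 nM.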

Compound 4, concentration for 50% growth inhibition: 4970 nM
Beside the measured number, compound 4's estimate is 3.3-fold (0.52 log units) below it, within the range that was stated.
By their numbers in this assay, from the lowest: compounds 2 and 3 (each within the scatter of the next); then compound 4; then compound 1.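

Octyl in place of 3-chlorophenyl on a carbonyl carbon gives an 8.0-fold higher number from compound 2 to compound 4 (0.90 log units; beyond the scatter) in this assay, the first measured pair to isolate this position. The group here can therefore be exchanged from an aromatic ring to an open chain with a real but limited loss of growth inhibition, so this position does affect the read-out.

Still open, as far as these compounds go, is how a shorter chain such as butyl, a longer chain such as dodecyl, or an unsubstituted phenyl would read at this carbonyl carbon. No measurement shown explains the size of this step.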